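Removing the methyl from compound 1: cytotoxicity in HCT-116 cells

This account rests on a few compounds, and the source may have more. Where it says the series, first, only, none or still open, it means among the compounds named here.

Measured compounds:
compound 1 `Cc1ccc(-c2cccc(S(=O)(=O)N3CCC(N4CCC(C)CC4)CC3)c2)cc1` — > 5000 nM
compound 2 `CC1CCN(C2CCN(S(=O)(=O)c3ccc(Br)cc3OC(F)(F)F)CC2)CC1` — > 5000 nM
compound 3 `CCCOc1ccc(S(=O)(=O)N2CCC(N3CCC(C)CC3)CC2)cc1` — > 5000 nM

All three compounds share a core and were tested in an ADME assay on HCT-116 cells (Homo sapiens) for cytotoxicity, read by CellTiter-Glo, with a stated time of 72 h; a higher number here means a weaker inhibitor, a lower number a stronger inhibitor. For compound 1 the result is a limit of the assay, > 5000 nM, not a number. Compound 2 likewise gives only a limit, > 5000 nM. Compound 3 also sits at a limit, > 5000 nM. So compound 1 cannot be placed against the others on this readout: every value shown is a limit, (the limit of > 5000 nM in this assay, at which 3 of the 3 values shown sit).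

Compound 4 `CC1CCN(C2CCN(S(=O)(=O)c3cccc(-c4ccccc4)c3)CC2)CC1` is the next compound. It differs from compound 1 by hydrogen in place of methyl on an aromatic carbon. For the measured compounds named here, with no measured step, there is no basis for expecting a direction; the step is expected to stay within the scatter, a step that the limit leaves unreadable from compound 1 to compound 4. Compound 4 is therefore estimated at 10000 nM, in the range 3000 nM to 40000 nM, most likely reported again as a limit.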

Compound 4, half-maximal inhibitory concentration: > 5000 nM
Compound 4: no number, only a limit (the forecaster's own chance of this, stated with the estimate: 80%); the middle value is on the limit's open side.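

Compound 1 and compound 4 each give only a limit of the assay, so no step can be read between them: the limit of > 5000 nM in this assay, at which 4 of the 4 values shown sit. The compounds shown leave open whether going from 4-methylphenyl to phenyl shifts the result at all, and where any of these compounds lies beyond that limit.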